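The source may report more compounds than this note shows. Statements on the series, on what has been measured and on what is new or still open speak of the compounds shown alone.

Two acids share one core in this set. Compound 3 `O=C(O)c1cnc2c(F)cccc2c1` bears fluoro, and in a functional assay on the whole organism (strain Sprague-Dawley) for inhibition, with Rattus norvegicus as the target (on this read-out lower numbers stand for an effect already at smaller amounts and higher numbers for an effect only at larger amounts of compound), compound 3 gives 150 mg/kg. Compound 1 `CCc1cccc2cc(C(=O)O)cnc12` bears ethyl in its place, and in this assay compound 1 gives 75 mg/kg. The change between them is ethyl in place of fluoro on an aromatic carbon, and the step it made is a 2.0-fold lower number from compound 3 to compound 1 (0.30 log units; within the scatter).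

Compound 2 `O=c1c(-c2nn[nH]n2)c[nH]c2ccc(F)cc12` is built on a different core; how the two cores differ is not broken down here. In this assay compound 2 gives only a limit, > 20 mg/kg. That is the limit of > 20 mg/kg in this assay, at which 1 of the 3 values shown sits.

Compound 4 `CCc1ccc2[nH]cc(-c3nn[nH]n3)c(=O)c2c1` is not yet measured. It differs from compound 2 by ethyl in place of fluoro on an aromatic carbon. The surroundings are not identical: here the place is meta to a fused ring and para to a fused ring, whereas in the measured pair it is ortho to a fused ring and meta to a fused ring, so this is the same kind of change, not the same. Because the measured step of a 2.0-fold lower number from compound 3 to compound 1 (0.30 log units; within the scatter) lies within the scatter, the step from compound 2 to compound 4 is expected to be small, a step that the limit leaves unreadable from compound 2 to compound 4. On that basis compound 4 is expected to give about 40 mg/kg, most likely between 15 mg/kg and 150 mg/kg.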

Compound 4, minimum effective dose: 0.625 mg/kg
Estimate against measurement, compound 4: 64-fold (1.81 log units) above, outside the stated range (below it).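

On the core of compound 2, ethyl in place of fluoro on an aromatic carbon gave an at least 32-fold lower number from compound 2 to compound 4 (1.50 log units; beyond the scatter) in this assay. Set beside the earlier step, the change did not carry over from one core to the other as a step of one size: the same change on two cores in this assay, a 2.0-fold lower number (0.30 log units; within the scatter) from compound 3 to compound 1 and an at least 32-fold lower number (1.50 log units; beyond the scatter) from compound 2 to compound 4, at least 16-fold (1.20 log units) apart, beyond the scatter of two such steps It does not show whether the core or the place of the change on the ring accounts for this gap, as the two pairs carry the change at different places, and two pairs give no rule for other cores.

From the compounds shown here alone, the value of compound 2 is only a limit, > 20 mg/kg, and the full size of the step on this core stays open. The compounds shown also leave open how a longer chain such as propyl, or an amine, would fare in place of the ethyl of compound 4, and what ethyl would do on the core of compound 1 at the place it holds in compound 4.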